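This account rests on a few compounds, and the source may have more. Where it says the series, first, only, none or still open, it means among the compounds named here.

Working notes on the series.

Compound 1 `NC(=O)c1cnc2ccc(-c3cccnc3)cc2c1SC1CCCC1` is the starting point. In an ADME assay on cells (Hepatocyte, Rattus norvegicus) for metabolic stability, with a stated time of 90 min (a lower number here means slower removal, a higher number faster removal of the compound), compound 1 gives 120 uL/min. Among the compounds with values here, compound 2 `CCC(CC)CNc1c(C(N)=O)cnc2ccc(-c3ccc(COC)cc3)cc12` is the only other compound with a number here; in this assay compound 2 gives 76 uL/min. Within the data shown here, compound 1 therefore carries the highest of the two numbers recorded, but the gap to compound 2 lies within the usual scatter of the method, so no order between the two can be read from these values, and no step between them is computed.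

Compound 3 `CCC(CC)COc1c(C(N)=O)cnc2ccc(-c3cccnc3)cc12` is the unmeasured compound. Relative to compound 1 the change is 2-ethylbutoxy in place of cyclopentylsulfanyl on an aromatic carbon. The replacement sits on the aromatic carbon ortho to the carbamoyl group of the shared core. Among the measured compounds shown here, only two numbers exist for the series, and neither compound 2 nor any other pair gives a step from which the effect of this replacement could be calibrated. The expectation for compound 3 is therefore a step from compound 1 of a 1.2-fold lower number from compound 1 to compound 3 (0.08 log units; within the scatter), in no direction beyond the scatter. Compound 3 is estimated at 100 uL/min, within a range of 50 uL/min to 200 uL/min in this assay.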

Compound 3, intrinsic clearance in a liver preparation (reported as CLH), per the amount of preparation that the assay uses: 260 uL/min
For compound 3 the middle estimate is 2.6-fold (0.41 log units) below the measured one; the measured number lies above the stated range.
By their numbers in this assay, from the lowest: compounds 2 and 1 (each within the scatter of the next); then compound 3.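

The aromatic carbon ortho to a carbamoyl group does not tolerate every replacement silently in this assay: 2-ethylbutoxy in place of cyclopentylsulfanyl gives a 2.2-fold higher number from compound 1 to compound 3 (0.34 log units; beyond the scatter), a modest step but the first in the series to lie beyond the scatter. This single step carries two differences at once, a group with a five-membered non-aromatic ring giving way to one with no ring and sulfur giving way to oxygen, so it cannot assign the change in number to either. Nothing measured on these compounds bears on the reason for the higher number.

The two differences remain to be separated: cyclopentyloxy on the same carbon would keep the ring and exchange only sulfur for oxygen, while 2-ethylbutylsulfanyl would keep the sulfur and give up the ring. As far as these compounds go, whether the step holds with a different group elsewhere on the shared core also stays open, as compound 2 differs from compound 3 in more than one place and gives no such comparison.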